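A few compounds are considered here, and "the series" means these few. Any claim that something is new, unique, unknown or untested is made for them only; others in the source may bear on it.

In a functional assay on THP-1 cells (Homo sapiens) (a lower number here means a stronger inhibitor, a higher number a weaker inhibitor), compound 1 (`CCSC[C@@](O)([C@@H](Nc1cccc2nc(C)ccc12)c1ccc(F)cc1OC)C(F)(F)F`) gives 5.01 nM, compound 2 (`CCSC[C@@](O)([C@@H](Nc1cc(F)cc2[nH]c(=O)ccc12)c1ccc(OC)c(F)c1Cl)C(F)(F)F`) gives 1.59 nM, and compound 3 (`CCOC[C@@](O)([C@@H](Nc1cc(F)cc2[nH]c(=O)ccc12)c1ccc(OC)c(F)c1Cl)C(F)(F)F`) gives 0.794 nM. Compound 3 therefore stands well under compound 1 but cannot be separated from compound 2.

Compound 4 (`COc1ccc([C@H](Nc2cc(F)cc3[nH]c(=O)ccc23)[C@](O)(CN(C)C)C(F)(F)F)c(Cl)c1F`) differs from compound 3 in one place, with dimethylamino in place of ethoxy on a saturated chain carbon, two bonds along the chain from an oxygen on a saturated carbon.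

Going by the values given here, only one measured step touches that place, the exchange of ethylsulfanyl for ethoxy, which gave a 2.0-fold lower number from compound 2 to compound 3 (0.30 log units; within the scatter). Among the compounds with values here, that step involves no dimethylamino group, and no measured compound carries one, so the direction of the new change is poorly supported. A small drift to a higher number is the cautious expectation, with no clear step beyond the scatter. The expected change is a 1.9-fold higher number from compound 3 to compound 4 (0.28 log units; within the scatter). For compound 4 the estimated value in this assay is 1.5 nM, within an expected range from 0.3 nM to 8 nM.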

Compound 4, half-maximal inhibitory concentration in the THP-1 assay: 7.94 nM
Compound 4: the middle estimate sits 5.3-fold (0.72 log units) below what was measured, within the range that was stated.
By their numbers in the THP-1 assay, from the lowest: compounds 3 and 2 (each within the scatter of the next); then compounds 1 and 4 (each within the scatter of the next).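

In the THP-1 assay this position proves sensitive to the group it carries: dimethylamino gives a 10-fold higher number from compound 3 to compound 4 (1.00 log units; beyond the scatter) and a 5.0-fold higher number from compound 2 to compound 4 (0.70 log units; beyond the scatter) against the ethoxy and ethylsulfanyl groups. Ethoxy and ethylsulfanyl could not be separated from each other, so among these three groups only dimethylamino stands apart here. In a physicochemical assay for lipophilicity (on this read-out lower numbers stand for lower lipophilicity and higher numbers for higher lipophilicity), compound 3 gives 3.8 and compound 4 gives 4.4. The same exchange thus also raises the number on this read-out, so in this pair the weaker inhibition comes with higher lipophilicity, not lower: the measured partition coefficient of compound 3, 3.8, and of compound 4, 4.4, a number 0.60 log units higher (beyond the scatter).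

The compounds shown leave open whether the higher number in the THP-1 assay follows from having an amine at this place at all or from dimethylamino in particular. A methylamino group or a morpholine on the same saturated chain carbon would bear on that question.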